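Trifluoromethyl to Carbamoyl: A Step from Compound 2

The source may report more compounds than this note shows. Statements on the series, on what has been measured and on what is new or still open speak of the compounds shown alone.

The three measured compounds and their numbers in an assay on isolated protein for inhibition of 2-Hydroxyacid oxidase 2 (Homo sapiens), tested at 10 uM; on this read-out lower numbers stand for a weaker effect and higher numbers for a stronger effect at the one concentration tested:

Compound 1, `Cc1n[nH]c(C(=O)O)c1Cc1cccc(-c2ccc(OC(F)(F)F)cc2)c1`, gives 34%.
Compound 2, `Cc1n[nH]c(C(=O)O)c1Cc1ccc(C(F)(F)F)cc1`, gives 12%.
Compound 3, `Cc1n[nH]c(C(=O)O)c1Cc1cccc(C(F)(F)F)c1`, gives 23%.

Among these three, compound 2 stands lowest in this assay. Its nearest neighbour is compound 3, whose number lies higher by a margin beyond the usual scatter, and compound 1 lies higher still, again beyond the scatter. Going by the values given here, no pair of these measured compounds differs in only one place, so no single step within the measured set can be read off.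

The unmeasured compound 4, `Cc1n[nH]c(C(=O)O)c1Cc1ccc(C(N)=O)cc1`, is reached from compound 2 by one change: carbamoyl in place of trifluoromethyl on an aromatic carbon. The trifluoromethyl is removed and a carbamoyl with one hydrogen-bond donor and one hydrogen-bond acceptor takes its place.

Nothing in the measured set tells how this assay responds to such a change, so the step in this assay from compound 2 to compound 4 is expected to be small, in no clear direction, and most likely within the scatter, as no change at the digits printed from compound 2 to compound 4 (within the scatter). The number for compound 4 in this assay is estimated at 12%, within a range from 0% to 32%.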

Compound 4, a percentage reported as inhibition, at one concentration (the size of the read-out at that concentration, not a potency): 8%
The estimate for compound 4 lay 4 percentage points above the measured number; the measured number falls inside the stated range.
By their numbers in this assay, from the lowest: compounds 4 and 2 (each within the scatter of the next); then compound 3; then compound 1.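

In this assay, going by these compounds alone, this is the first comparison that isolates one place: carbamoyl in place of trifluoromethyl on an aromatic carbon, para to a large group, gives a number 4 percentage points lower from compound 2 to compound 4 (within the scatter) for this pair. At this position, the read-out therefore does not tell the two groups apart, even though the carbamoyl carries a hydrogen-bond donor and a hydrogen-bond acceptor and the trifluoromethyl carries neither. No measurement is available here that bears on the reason for this result.

On these data alone, it remains open whether other groups at the same position, such as an amine, a carboxylic acid or a nitrile, would also stay within the scatter of compound 2 in this assay. Also unresolved is whether the carbamoyl would give a similarly small step if it took the place of the trifluoromethyl in compound 3, where that group stands elsewhere on the ring, or whether this exchange is tolerated only at the position seen in compound 2.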